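From ethylamino to acetamido in a level series

This account rests on a few compounds, and the source may have more. Where it says the series, first, only, none or still open, it means among the compounds named here.

Measured so far in a functional assay on HCT-116 cells (Homo sapiens) for antiproliferative activity, read by sulforhodamine B assay, with a stated time of 72 h; a higher number here means a weaker inhibitor, a lower number a stronger inhibitor
compound 1 `CCNc1cnc2ccc(-c3cnc(OC)c(NS(=O)(=O)c4ccc(F)cc4F)c3)cc2c1OC` gives 1850 nM
compound 2 `COc1ncc(-c2ccc3ncc(NC(=O)CN4CCN(C)CC4)c(OC)c3c2)cc1NS(=O)(=O)c1ccc(F)cc1F` gives 1540 nM
compound 3 `COc1ncc(-c2ccc3ncc(NCC4CCN(C(C)=O)CC4)c(OC)c3c2)cc1NS(=O)(=O)c1ccc(F)cc1F` gives 1930 nM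
compound 4 `COc1ncc(-c2ccc3ncc(NC(C)=O)c(OC)c3c2)cc1NS(=O)(=O)c1ccc(F)cc1F` is not yet measured

Compound 1 stands level with the other two, since neither step from it leaves the scatter. Compound 4 shares the core of compound 1 and carries acetyl in place of ethyl on a nitrogen on an aromatic ring. The closest evidence is the change to compound 2, which also puts a carbonyl on that nitrogen and gives a 1.2-fold lower number from compound 1 to compound 2 (0.08 log units; within the scatter) as its step. The change to compound 3 keeps a saturated chain there and gives a 1.0-fold higher number from compound 1 to compound 3 (0.02 log units; within the scatter) as its step. Neither offers a reason to expect movement, so no step beyond the scatter is expected in this assay for this change. The expected step is a 1.1-fold lower number from compound 1 to compound 4 (0.04 log units; within the scatter) as an estimate only. The estimated value for compound 4 is 1700 nM within an expected range of 800 nM to 3600 nM.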

Compound 4, half-maximal inhibitory concentration: 550 nM
Beside the measured number, compound 4's estimate is 3.1-fold (0.49 log units) above it; the measured number lies below the stated range.
By their numbers in this assay, from the lowest: compound 4; then compounds 2, 1 and 3 (each within the scatter of the next).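

In this assay, going by these compounds alone, the group on this nitrogen on an aromatic ring can shift the number after all: acetyl in place of ethyl gives a 3.4-fold lower number from compound 1 to compound 4 (0.53 log units; beyond the scatter), whereas the earlier compounds stayed level with one another. A carbonyl on that nitrogen is not enough by itself, since hydrogen in place of 4-methylpiperazin-1-yl on the saturated chain carbon bound to that carbonyl gives a 2.8-fold lower number from compound 2 to compound 4 (0.45 log units; beyond the scatter). The small acetyl also separates from the larger (1-acetylpiperidin-4-yl)methyl, with a 3.5-fold lower number from compound 3 to compound 4 (0.55 log units; beyond the scatter).

Going by these compounds, whether the step survives on lengthening the acyl chain to propanoyl, or on replacing it with a methanesulfonyl group or a free amine, stays open. Nothing in the data shown explains why acetyl differs from ethyl at this position.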